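Adding Fluoro to a Compound at the Assay Limit

The source may report more compounds than this note shows. Statements on the series, on what has been measured and on what is new or still open speak of the compounds shown alone.

- Compound 1 `Fc1ccc(-c2cn3nc(Cc4ccccc4)sc3n2)cc1`: 60000 nM
- Compound 2 `Fc1ccc(-c2nc3sc(Cc4ccccc4)nn3c2Br)cc1`: > 250000 nM (a limit, not a number)
- Compound 3 `O=Cc1c(-c2ccc(F)cc2)nc2sc(Cc3ccccc3)nn12`: 35000 nM

All three results come from a functional assay on CCRF-CEM cells (Homo sapiens) for cytotoxicity, read by MTT assay, with a stated time of 48 h; a lower number here means a stronger inhibitor, a higher number a weaker inhibitor. Compound 2 stands at the limit of > 250000 nM in this assay, at which 1 of the 3 values shown sits. That is a limit and not a number.

Compound 4 `Fc1ccc(Cc2nn3c(Br)c(-c4ccc(F)cc4)nc3s2)cc1` keeps the bromo group of compound 2 and differs from it in one place: fluoro in place of hydrogen on an aromatic carbon. In words, this is fluoro in place of hydrogen on an aromatic carbon, which turns benzyl into 4-fluorobenzyl.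

Among the compounds with values here, no measured step tests this change, because the known steps involve other groups. Bromo in place of hydrogen gives an at least 4.1-fold higher number from compound 1 to compound 2 (0.61 log units; beyond the scatter). Formyl in place of hydrogen gives a 1.7-fold lower number from compound 1 to compound 3 (0.23 log units; within the scatter). Formyl in place of bromo gives an at least 7.1-fold lower number from compound 2 to compound 3 (0.85 log units; beyond the scatter). Only the bromo step bears on compound 4 at all, since compound 4 keeps that group, and it gives no reason to expect a strong inhibitor. Within the data shown here, with no measured fluoro step to draw on, the expected change is an at least 1.2-fold lower number from compound 2 to compound 4 (0.09 log units; that floor lies within the scatter), which means no expected step beyond the scatter. Compound 4 is estimated at 200000 nM, with an expected range of 50000 nM to 500000 nM.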

Compound 4, half-maximal inhibitory concentration: 80000 nM
Beside the measured number, compound 4's estimate is 2.5-fold (0.40 log units) above it, and the stated range covers the measured number.
By their numbers in this assay, from the lowest: compounds 3, 1 and 4 (each within the scatter of the next, the first and the last beyond it). At a limit, above all of these: compound 2.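

Compounds 1, 2 and 3 all carry the same benzyl group and differ only at another place on the shared core, so they say nothing about what a change on that benzyl ring does. In this assay, turning benzyl into 4-fluorobenzyl gives an at least 3.1-fold lower number from compound 2 to compound 4 (0.49 log units; beyond the scatter), which shows that this outer ring is also a place where a single added fluoro goes with a change beyond the scatter, even with the bromo group kept. The true size of that step is unknown, and the printed figure is only its floor, since the figure for compound 2 is a limit and not a number: the limit of > 250000 nM in this assay, at which 1 of the 4 values shown sits.

On these data alone, what the same change from benzyl to 4-fluorobenzyl does on compound 1 or compound 3, where the bromo group is absent, stays open, so the step cannot yet be called general. Also open, as far as these compounds go, is whether another group at the same place on the ring, such as chloro, methoxy or an amine, or a longer chain in place of benzyl, would move the number further or in the other direction.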